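Indolyl pyran series: aryl swap at the saturated carbon

A few compounds are considered here, and "the series" means these few. Any claim that something is new, unique, unknown or untested is made for them only; others in the source may bear on it.

Going by the values given here, compound 2 `CN(C)c1ccc(C2C(C#N)=C(N)OC(c3c[nH]c4ccccc34)=C2C#N)cc1` holds the only number so far: in a functional assay, tested at 100 ug/mL (on this read-out higher numbers stand for a stronger effect at the one concentration tested and lower numbers for a weaker effect), compound 2 gives 18.5%. Compound 1 `N#CC1=C(N)OC(c2c[nH]c3ccccc23)=C(C#N)C1c1ccccc1F` is reported in this assay as "not active" (no number reported), without a number. Compound 3 `Cc1ccccc1C1C(C#N)=C(N)OC(c2c[nH]c3ccccc23)=C1C#N` is not yet measured; it differs from compound 2 by 2-methylphenyl in place of 4-(dimethylamino)phenyl on a saturated ring carbon. Among the compounds with values here, no step between two measured compounds is known, so the size of this move rests on little. A decrease at or somewhat beyond the scatter is expected, because compound 1 gives "not active" (no number reported) in this assay. The expected step is a number 9.5 percentage points lower from compound 2 to compound 3 (within the scatter). For compound 3 the estimate in this assay is 9%, within 0% to 22%.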

Compound 3, a percentage reported as activity, at one concentration (the size of the read-out at that concentration, not a potency): 17.2%
Estimate against measurement, compound 3: 8.2 percentage points below, and the stated range covers the measured number.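

In this assay, going by these compounds alone, the swap gives a number 1.3 percentage points lower from compound 2 to compound 3 (within the scatter) and so provides the first readable step at this saturated ring carbon. The two aryl groups cannot be told apart on this read-out, so a measurable effect here does not depend on the dimethylamino group. Compound 1 stays at "not active" (no number reported) and its steps cannot be read, although its 2-fluorophenyl group differs from the 2-methylphenyl of compound 3 only in fluorine for methyl.

On these data alone, whether a 4-methoxyphenyl or a 4-carboxyphenyl group at this carbon would stay in the same range remains open. No measurement shown explains why these aryl groups read alike or why compound 1 gives no number.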